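The source may hold more compounds than are shown below. What is called first, only, known or untested is meant among the compounds shown, and "the series" means these compounds.

Measured in an ADME assay on HEK-293T cells (Homo sapiens) for inhibition, read by CCK-8 assay, with a stated time of 48 h; a lower number here means a stronger inhibitor, a higher number a weaker inhibitor:
- compound 1 `COc1ccc(Cc2nnc(NC(=O)/C(C#N)=C/c3ccccc3OS(=O)(=O)c3ccc(OC)cc3)s2)cc1`: > 50000 nM (a limit)
- compound 2 `COc1ccc(S(=O)(=O)Oc2ccccc2/C=C(\C#N)C(=O)Nc2nnc(Cc3ccccc3)s2)cc1`: > 50000 nM (a limit)

Going by the values given here, compound 2 has no number, only a limit, and the series so far sits at the limit of > 50000 nM in this assay, at which 2 of the 2 values shown sit. Compound 3 `COc1ccc(S(=O)(=O)Oc2ccccc2/C=C(\C#N)C(=O)Nc2nnc(Cc3ccc(F)cc3)s2)cc1` differs from it by fluoro in place of hydrogen on an aromatic carbon, taking benzyl to 4-fluorobenzyl. Among the compounds with values here, the only measured step is a step that the two limits leave unreadable from compound 1 to compound 2, a different change, so it offers no size to carry over. The expected step, a number no higher from compound 2 to compound 3 (the limit leaves the size open), is therefore none beyond the scatter, in neither direction. In this assay the estimate for compound 3 is 50000 nM, with an expected range of 25000 nM to 100000 nM, most likely reported again as a limit.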

Compound 3, half-maximal inhibitory concentration: > 50000 nM
Compound 3 ended at the assay's limit; the forecaster's own chance of this, stated with the estimate: 85%; the middle value lies on the limit itself.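

No step can be read among compound 1, compound 2 and compound 3 in this assay, as each gives only a limit: the limit of > 50000 nM in this assay, at which 3 of the 3 values shown sit.

The compounds shown leave open whether fluoro in place of hydrogen or hydrogen in place of methoxy changes inhibition at all.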